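Five-membered ring swap on the shared core

The compounds below may be only part of what the source reports. "The series", "measured", "known", "first", "only" and "open" are said of these compounds alone.

Compound 1 `Cc1ccsc1-c1ncnc2c1ncn2C1O[C@H](CO)[C@@H](O)[C@H]1O` gives 4500 nM in a functional assay on HL-60 cells (Homo sapiens) for inhibition; on this read-out lower numbers stand for stronger inhibition and higher numbers for weaker inhibition. Compound 2 `Cn1cccc1-c1ncnc2c1ncn2C1O[C@H](CO)[C@@H](O)[C@H]1O` gives 15700 nM in this assay, a change of a 3.5-fold higher number from compound 1 to compound 2 (0.54 log units; beyond the scatter). Compound 3 `OC[C@H]1OC(n2cnc3c(-c4nccs4)ncnc32)[C@H](O)[C@@H]1O` gives 6300 nM in this assay, the second highest of the three numbers; the gap a 1.4-fold higher number from compound 1 to compound 3 (0.15 log units; within the scatter) is within the scatter, while a 2.5-fold lower number from compound 2 to compound 3 (0.40 log units; beyond the scatter) lies beyond it. Compound 4 `OC[C@H]1OC(n2cnc3c(-c4cc[nH]n4)ncnc32)[C@H](O)[C@@H]1O` differs from compound 3 by 1H-pyrazol-3-yl in place of 1,3-thiazol-2-yl on an aromatic carbon. Within the data shown here, the ring swaps seen so far, a 1.4-fold higher number from compound 1 to compound 3 (0.15 log units; within the scatter) and a 2.5-fold lower number from compound 2 to compound 3 (0.40 log units; beyond the scatter), were small to modest, so no step clearly beyond the scatter is expected in this assay for compound 4, whose expected step is a 1.0-fold higher number from compound 3 to compound 4 (0.01 log units; within the scatter). Compound 4 is estimated at 6500 nM, with a range from 2500 nM to 17000 nM.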

Compound 4, half-maximal inhibitory concentration: 1170 nM
The estimate for compound 4 lay 5.6-fold (0.74 log units) above the measured number; measured number outside the range, below it.
By their numbers in this assay, from the lowest: compound 4; then compounds 1 and 3 (each within the scatter of the next); then compound 2.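

In this assay this position on the shared core proves sensitive to the choice of five-membered ring: 1H-pyrazol-3-yl gives a 5.4-fold lower number from compound 3 to compound 4 (0.73 log units; beyond the scatter) with the same count of 5 heavy atoms, bringing 1 hydrogen-bond donor where 1,3-thiazol-2-yl has 0. The same group gives a 3.8-fold lower number from compound 1 to compound 4 (0.59 log units; beyond the scatter) and a 13-fold lower number from compound 2 to compound 4 (1.13 log units; beyond the scatter) and so makes compound 4 the most potent of the four. Nothing available accounts for this gain.

As far as these compounds go, whether the gain follows the ring hydrogen stays open. A 1-methyl-1H-pyrazol-3-yl group or an imidazolyl ring at this position would test that.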